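Swapping the Thiophene Substituent in a Sulfonylurea Series

The source may hold more compounds than are shown below. What is called first, only, known or untested is meant among the compounds shown, and "the series" means these compounds.

Measured compounds:
compound 1, `CCc1ccc(S(=O)(=O)NC(=O)Nc2ccc(Cl)cc2)s1`: 57%
compound 2, `CC(C)(C)c1ccc(S(=O)(=O)NC(=O)Nc2ccc(Cl)cc2)s1`: 7%

Compound 1 stands highest of the two numbers in a functional assay on the whole organism (6C3HED cells, Mus musculus) for inhibition, at a dose of 150 mg/kg by the oral route; on this read-out higher numbers stand for more inhibition at the one dose given (going by the name of the read-out) and lower numbers for less inhibition; its nearest neighbour is compound 2, which sits a number 50 percentage points lower from compound 1 to compound 2 (beyond the scatter) after tert-butyl replaces ethyl on an aromatic carbon. That single step is the only measured one, and it shows that a change on the 5-ethylthiophen-2-yl part of the shared core can pull the inhibition down sharply.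

Compound 3, `O=C(Nc1ccc(Cl)cc1)NS(=O)(=O)c1cc(Br)c(Br)s1`, has not yet been measured in this assay. It differs from compound 1 in this way: 4,5-dibromothiophen-2-yl in place of 5-ethylthiophen-2-yl on a sulfonyl sulfur. Among the compounds with values here, the change sits on the same ring that carried the ethyl group, but it removes that alkyl group entirely and brings in two bromines, so the one measured step bears on it only loosely. The step from compound 1 to compound 2 was large and downward; a step of similar direction but of uncertain size is therefore the most defensible expectation.

Compound 3 is expected to give about 35%, somewhere between 5% and 65%, which would mean an expected a number 22 percentage points lower from compound 1 to compound 3 (beyond the scatter).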

Compound 3, a percentage reported as inhibition, in the whole organism at one dose (the size of the read-out at that dose, not a potency): 25%
Compound 3: middle estimate off by 10 percentage points, on the high side; the range from low to high includes it.
By their numbers in this assay, from the lowest: compound 2; then compound 3; then compound 1.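

In this assay the move to 4,5-dibromothiophen-2-yl on a sulfonyl sulfur gives a number 32 percentage points lower from compound 1 to compound 3 (beyond the scatter) and so joins the tert-butyl change, which gave a number 50 percentage points lower from compound 1 to compound 2 (beyond the scatter) as a second downward step at this part of the shared core. Within the data shown here, the earlier pair showed only one alkyl group replacing another, whereas this change removes the ethyl group altogether and brings in two bromines, and the number still falls beyond the scatter. The leaving and entering groups match in heavy-atom count, in their five-membered aromatic ring and in their hydrogen-bond donors and acceptors, so a fall of this kind can occur with those counts unchanged, and nothing available here explains either fall.

On these data alone, whether a single bromine, as in 5-bromothiophen-2-yl, would stand closer to the ethyl compound remains open, and so does the separate contribution of each of the two bromines. Also open, as far as these compounds go, is how a shorter or longer chain, such as methyl or propyl, or a group of another kind, such as an amine or a carboxylic acid, would fare on this ring.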